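Swapping the benzylidene aryl group of a semicarbazone series

A few compounds are considered here, and "the series" means these few. Any claim that something is new, unique, unknown or untested is made for them only; others in the source may bear on it.

Measured so far in a functional assay on HT-29 cells (Homo sapiens) for cytotoxicity, read by MTT assay, with a stated time of 72 h; a higher number here means a weaker inhibitor, a lower number a stronger inhibitor:
- compound 1 `COc1ccc(/C=N/NC(=O)Nc2ccc(Oc3ccnc(-c4nncn4CCN(C)C)c3)c(F)c2)c(OC)c1` gives 1780 nM
- compound 2 `CN(C)CCn1cnnc1-c1cc(Oc2ccc(NC(=O)N/N=C/c3ccc(O)c(Br)c3)cc2F)ccn1` gives 450 nM
- compound 3 `CN(C)CCn1cnnc1-c1cc(Oc2ccc(NC(=O)N/N=C/c3cccc(Br)c3)cc2F)ccn1` gives 380 nM

Compound 3 gives the lowest of the three numbers, though its gap to compound 2 is within the scatter, so the two cannot be ranked against each other; only compound 1 stands clearly apart, as shown by a 4.7-fold lower number from compound 1 to compound 3 (0.67 log units; beyond the scatter) and a 4.0-fold lower number from compound 1 to compound 2 (0.60 log units; beyond the scatter).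

Compound 4 `CN(C)CCn1cnnc1-c1cc(Oc2ccc(NC(=O)N/N=C/c3ccc(O)c(F)c3)cc2F)ccn1` keeps the shared core and differs from compound 3 in one place: 3-fluoro-4-hydroxyphenyl in place of 3-bromophenyl on a carbon with a double bond to nitrogen.

Among the measured compounds shown here, two measured steps bear on this change. Adding a hydroxy beside a bromine, which is the reverse of the step of a 1.2-fold lower number from compound 2 to compound 3 (0.07 log units; within the scatter), changed the number by an amount within the scatter. For the measured compounds named here, no measured pair tests a bromine against a fluorine on this aryl group, so that part of the change is unsupported by data. On that basis compound 4 is expected to sit close to compound 3, with the estimate allowing for a small loss rather than a gain: a 1.6-fold higher number from compound 3 to compound 4 (0.20 log units; within the scatter). The estimated number for compound 4 in this assay is 600 nM, with a range from 250 nM to 1500 nM.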

Compound 4, half-maximal inhibitory concentration: 3310 nM
Beside the measured number, compound 4's estimate is 5.5-fold (0.74 log units) below it, outside the stated range (above it).
By their numbers in this assay, from the lowest: compounds 3 and 2 (each within the scatter of the next); then compounds 1 and 4 (each within the scatter of the next).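

Within this assay the step of a 7.4-fold higher number from compound 2 to compound 4 (0.87 log units; beyond the scatter) is the only measured pair that tests fluoro in place of bromo on an aromatic carbon, and it lies beyond the scatter, whereas the step that removed the hydroxy stayed within it. This shows that at this aryl group the halogen can move the number where the hydroxy did not, and the full replacement of 3-bromophenyl by 3-fluoro-4-hydroxyphenyl gives an 8.7-fold higher number from compound 3 to compound 4 (0.94 log units; beyond the scatter) as the measured result. The step of a 1.9-fold higher number from compound 1 to compound 4 (0.27 log units; within the scatter) lies within the scatter, so 3-fluoro-4-hydroxyphenyl and 2,4-dimethoxyphenyl cannot be ranked against each other here, and the data offer no measured explanation for the effect of exchanging the halogen.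

The compounds shown leave open whether the hydroxy counts for as little alongside fluorine as it does alongside bromine, a question that a 3-fluorophenyl group on the same carbon would address. They also leave open whether bromine alone gives the lower numbers, or whether a 3-chlorophenyl or 3-methylphenyl group would stand with compound 3 rather than with compound 4.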